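A nitro group on compound 2

The source may report more compounds than this note shows. Statements on the series, on what has been measured and on what is new or still open speak of the compounds shown alone.

In a functional assay on HCT-116 cells (Homo sapiens) for inhibition, read by sulforhodamine B assay, with a stated time of 48 h, tested at 50 uM (on this read-out higher numbers stand for more inhibition of growth at the one concentration tested and lower numbers for less inhibition of growth), compound 2 `O=C1C(=O)N(CCCCCn2cc(COc3cc(=O)oc4ccccc34)nn2)c2ccccc21` gives 65% and stands highest of the two measured compounds, with compound 1 `O=C1C(=O)N(CCCCCn2cc(COc3cc(=O)oc4ccccc34)nn2)c2ccc(I)cc21` lower at 36% on the same scale. Compound 3 `O=C1C(=O)N(CCCCCn2cc(COc3cc(=O)oc4ccccc34)nn2)c2ccc([N+](=O)[O-])cc21` differs from compound 2 by nitro in place of hydrogen on an aromatic carbon, counted as nitro in place of hydrogen on an aromatic carbon in the two structures. Within the data shown here, the only measured step bearing on this is a number 29 percentage points higher from compound 1 to compound 2 (beyond the scatter) with hydrogen replacing iodo on an aromatic carbon, and read backwards it leads to the expectation of a modest fall beyond the scatter, though nitro is not iodo. In this assay the estimated change is a number 20 percentage points lower from compound 2 to compound 3 (beyond the scatter) on this reasoning. Compound 3 is expected at 45% with an estimated range from 25% to 65% as its likely span.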

Compound 3, percent growth inhibition at one concentration: 29%
Compound 3: middle estimate off by 16 percentage points, on the high side; low and high end bracket the measured number.
By their numbers in this assay, from the lowest: compounds 3 and 1 (each within the scatter of the next); then compound 2.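

In this assay, nitro in place of hydrogen on this aromatic carbon brings a number 36 percentage points lower from compound 2 to compound 3 (beyond the scatter), so the fall from the unsubstituted compound is not confined to iodo. Nitro in place of iodo gives a number 7 percentage points lower from compound 1 to compound 3 (within the scatter), and these two substituents cannot be told apart on this read-out. Nothing available accounts for this result. On these data alone, it remains open whether an amine, a methoxy group or fluoro on the same carbon would also lower the number. The compounds shown also leave open whether any group here matches hydrogen.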